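The source may report more compounds than this note shows. Statements on the series, on what has been measured and on what is new or still open speak of the compounds shown alone.

Measured so far in a physicochemical assay for metabolic stability, read by HPLC; a higher number here means that the compound lasts longer, a lower number that the compound disappears faster:
- compound 1 `Cc1cn([C@H]2C[C@H](N=[N+]=[N-])[C@@H](COP(=O)(O)Oc3ccccc3)O2)c(=O)[nH]c1=O`: 9.47 h
- compound 2 `O=c1ccn([C@H]2CC[C@@H](COP(=O)(O)Oc3ccccc3)O2)c(=O)[nH]1`: 25.1 h
- compound 3 `Cc1cn([C@H]2C[C@H](N=[N+]=[N-])[C@@H](COP(=O)(O)Oc3ccc(Cl)cc3Cl)O2)c(=O)[nH]c1=O`: 3.03 h

Compound 3 gives the lowest of the three numbers in this assay. Its nearest neighbour is compound 1, whose value stands higher by a step shown as beyond the scatter; compound 2 stands furthest away, also beyond the scatter. Compound 2 differs from compound 1 in more than one place, so only the two values can be compared for that pair.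

The next compound in the series is compound 4 `Cc1cn([C@H]2C[C@H](N=[N+]=[N-])[C@@H](COP(=O)(O)Oc3cncc(Cl)c3)O2)c(=O)[nH]c1=O`. Relative to compound 3 the change is 5-chloropyridin-3-yl in place of 2,4-dichlorophenyl on an oxygen.

Within the data shown here, one measured step bears on this: a 3.1-fold lower number from compound 1 to compound 3 (0.49 log units; beyond the scatter). It shows that the aryl group on the oxygen matters for this assay, and that going from phenyl to 2,4-dichlorophenyl lowered the number by a modest amount. Among the measured compounds shown here, no measured step covers a pyridinyl on that oxygen, nor a single chlorine on the ring, so the direction for compound 4 rests on that one step only. Removing one of the two chlorines and moving toward a less substituted ring is read as a partial return toward compound 1, so a modest rise is expected, though a number within the scatter of compound 3 cannot be excluded.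

For compound 4 the estimate is 5 h, with a range from 2 h to 12 h, corresponding to a 1.7-fold higher number from compound 3 to compound 4 (0.22 log units; within the scatter).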

Compound 4, half-life: 7.27 h
The estimate for compound 4 lay 1.5-fold (0.16 log units) below the measured number; the range from low to high includes it.
By their numbers in this assay, from the lowest: compound 3; then compounds 4 and 1 (each within the scatter of the next); then compound 2.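

In this assay, the aryl group on an oxygen whose other neighbours are phosphorus can also move the number upward: 5-chloropyridin-3-yl in place of 2,4-dichlorophenyl gives a step beyond the scatter (a 2.4-fold higher number from compound 3 to compound 4 (0.38 log units; beyond the scatter)), whereas the earlier step at this position ran downward (a 3.1-fold lower number from compound 1 to compound 3 (0.49 log units; beyond the scatter)). The low number of compound 3 is therefore not shared by every chlorine-bearing ring at this position, since 5-chloropyridin-3-yl stays within the scatter of plain phenyl (a 1.3-fold lower number from compound 1 to compound 4 (0.11 log units; within the scatter)). The data on hand give no cause for either step.

On these data alone, the step to compound 4 removes a chlorine and brings in a ring nitrogen at once, so the share of each remains open; a plain pyridinyl or a phenyl carrying a single chlorine would separate the two. Also open are whether these aryl steps carry over to the core of compound 2, which is shown only with phenyl, and how an amine or a carboxylic acid on the ring would read in this assay.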